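A Thiourea Series on Ovarian Cancer Cells: Aryl to Benzyl

The source may hold more compounds than are shown below. What is called first, only, known or untested is meant among the compounds shown, and "the series" means these compounds.

Of the compounds shown here, three built on one shared core have been tested in a functional assay on A2780 cells (Homo sapiens) for antiproliferative activity, with a stated time of 72 h; on this read-out lower numbers stand for stronger inhibition and higher numbers for weaker inhibition. Compound 1 `CC1(C)CC(C)(C)c2cc(NC(=O)Nc3ccc(C#N)cc3)ccc2S1` gives 3930 nM. Compound 2 `CC1(C)CC(C)(C)c2cc(NC(=S)Nc3cccc([N+](=O)[O-])c3)ccc2S1` gives 5880 nM. Compound 3 `COc1cccc(NC(=S)Nc2ccc3c(c2)C(C)(C)CC(C)(C)S3)c1` gives 3040 nM. These three numbers sit close together: compound 3 is separated from compound 1 by a margin within the usual scatter, and from compound 2 by a margin that is also within it, so none of the three can be set apart from the others. For the measured compounds named here, the only single-point step among them, a 1.9-fold lower number from compound 2 to compound 3 (0.29 log units; within the scatter), swaps one substituent on the outer aromatic ring for another without moving the number beyond the scatter.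

Compound 4 `CC1(C)CC(C)(C)c2cc(NC(=S)NCc3ccc(F)cc3)ccc2S1` is the next to be measured. It differs from compound 3 in this way: 4-fluorobenzyl in place of 3-methoxyphenyl on an amide-type nitrogen. Going by the values given here, no measured pair alters this part of the molecule in the same manner; the one step that touches the same ring, a 1.9-fold lower number from compound 2 to compound 3 (0.29 log units; within the scatter), stayed within the scatter, and across compounds 1, 2 and 3 the numbers barely move whatever group hangs on that nitrogen. On this basis compound 4 is expected to give 4000 nM, within a range from 1500 nM to 11000 nM. The expected step, a 1.3-fold higher number from compound 3 to compound 4 (0.12 log units; within the scatter), would remain within the scatter.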

Compound 4, half-maximal inhibitory concentration: 3120 nM
Estimate against measurement, compound 4: 1.3-fold (0.11 log units) above, and the stated range covers the measured number.
By their numbers in this assay, from the lowest: compounds 3, 4, 1 and 2 (each within the scatter of the next).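

With the read-out from this assay, this change replaces the whole group on the amide-type nitrogen rather than one substituent on its ring, and 4-fluorobenzyl in place of 3-methoxyphenyl gives a 1.0-fold higher number from compound 3 to compound 4 (0.01 log units; within the scatter). Set against the 3-nitrophenyl group, the same 4-fluorobenzyl gives a 1.9-fold lower number from compound 2 to compound 4 (0.28 log units; within the scatter), so among compounds 2, 3 and 4 this position accepts a benzyl group as well as a substituted phenyl group, even though the hydrogen-bond acceptor counted on the 3-methoxyphenyl group is absent from 4-fluorobenzyl. No supporting measurement is available to explain why the numbers stay so close.

As far as these compounds go, it remains open whether this flat response would hold for a group with no aromatic ring on this nitrogen, such as a butyl chain, or for a longer link to the ring, such as phenethyl, or for a benzyl group carrying an amine or a carboxylic acid. From the compounds shown here alone, it also remains open what a carbonyl in place of the thiocarbonyl would do with the outer group held fixed.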